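Ring size to chain at the aromatic nitrogen substituent

This account rests on a few compounds, and the source may have more. Where it says the series, first, only, none or still open, it means among the compounds named here.

Measured so far in an assay on isolated protein for inhibition of aldehyde dehydrogenase 1A1 (Homo sapiens), read by spectrophotometry, tested at 10 uM; on this read-out higher numbers stand for more inhibition at the one concentration tested (going by the name of the read-out) and lower numbers for less inhibition:
compound 1 `O=C(C1CC1)N1CCN(Cc2nc3ccccc3n2CC2CC2)CC1` gives 21.2%
compound 2 `O=C(C1CC1)N1CCN(Cc2nc3ccccc3n2CC2CCCC2)CC1` gives 44.5%

Compound 2 stands highest of the two numbers seen; compound 1 is the nearest, and the step of a number 23.3 percentage points higher from compound 1 to compound 2 (beyond the scatter) lies beyond the scatter. Compound 3 `CCCCn1c(CN2CCN(C(=O)C3CC3)CC2)nc2ccccc21` is not yet measured. Its difference from compound 2 is propyl in place of cyclopentyl on a saturated chain carbon bound to an aromatic nitrogen.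

Within the data shown here, the one measured step bears on this change only loosely: it compares two rings on the saturated chain carbon bound to the aromatic nitrogen, and the larger ring gave the higher number. Propyl carries fewer heavy atoms than cyclopentyl but is no ring, so the step is expected to be a moderate drop rather than a return to the level of compound 1. For compound 3 the expected step is a number 12.5 percentage points lower from compound 2 to compound 3 (beyond the scatter), with the estimate 32% in a range from 15% to 50%.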

Compound 3, a percentage reported as inhibition, at one concentration (the size of the read-out at that concentration, not a potency): 18.2%
Compound 3: the middle estimate sits 13.8 percentage points above what was measured; the measured number falls inside the stated range.
By their numbers in this assay, from the lowest: compounds 3 and 1 (each within the scatter of the next); then compound 2.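

In this assay the open chain does not hold the level reached with cyclopentyl: propyl in place of cyclopentyl on a saturated chain carbon bound to an aromatic nitrogen gives a number 26.3 percentage points lower from compound 2 to compound 3 (beyond the scatter), which is a step of about the same size as the earlier gain from the ring change. Propyl in place of cyclopropyl gives a number 3 percentage points lower from compound 1 to compound 3 (within the scatter), so these two groups cannot be told apart here, and among the three compounds only cyclopentyl stands out. No supporting measurement is available to explain why cyclopentyl stands apart.

On these data alone, it remains open whether the higher number needs a ring of this size, as a cyclohexyl or cycloheptyl group would test. A phenyl group or a branched chain such as isopentyl at this place would show whether ring closure itself matters.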